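From Phenylcarbamoyl to Thiophen-2-ylsulfonyl on the Ring Nitrogen

This account rests on a few compounds, and the source may have more. Where it says the series, first, only, none or still open, it means among the compounds named here.

Going by the values given here, in an assay for binding affinity to Adrenergic receptor alpha-1 (Rattus norvegicus) (a lower number here means a stronger inhibitor, a higher number a weaker inhibitor), compound 3 `COc1cc2nc(N3CCN(C(=O)Nc4ccccc4)CC3)nc(N)c2cc1OC` gives 27.5 nM, the highest of the three numbers so far: compound 1 `COc1cc2nc(N3CCN(C(=O)CCc4ccccc4)CC3)nc(N)c2cc1OC` gives 3.39 nM and compound 2 `COc1cc2nc(N3CCN(C(=O)COc4ccccc4)CC3)nc(N)c2cc1OC` gives 12.6 nM. Compound 4 `COc1cc2nc(N3CCN(S(=O)(=O)c4cccs4)CC3)nc(N)c2cc1OC` differs from compound 3 by (thiophen-2-yl)sulfonyl in place of phenylcarbamoyl on an amine nitrogen in a ring. Among the compounds with values here, no measured step involves a sulfonyl group, so the only guides are the swaps around the carbonyl carbon, an 8.1-fold higher number from compound 1 to compound 3 (0.91 log units; beyond the scatter) and a 2.2-fold higher number from compound 2 to compound 3 (0.34 log units; beyond the scatter), together with a 3.7-fold higher number from compound 1 to compound 2 (0.57 log units; beyond the scatter), all modest. On that basis a modest move in this assay is expected, in either direction, with a weaker number judged a little more likely. Compound 4 is therefore estimated at 40 nM, within 8 nM to 200 nM. The expected step is a 1.5-fold higher number from compound 3 to compound 4 (0.16 log units; within the scatter).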

Compound 4, half-maximal inhibitory concentration: 33.9 nM
Compound 4: the middle estimate sits 1.2-fold (0.07 log units) above what was measured; low and high end bracket the measured number.
By their numbers in this assay, from the lowest: compound 1; then compound 2; then compounds 3 and 4 (each within the scatter of the next).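

In this assay, the ring nitrogen accepts a sulfonyl link as readily as the urea-type carbonyl of phenylcarbamoyl: the exchange gives a 1.2-fold higher number from compound 3 to compound 4 (0.09 log units; within the scatter) even though the hydrogen-bond donor is lost. The same group gives a 2.7-fold higher number from compound 2 to compound 4 (0.43 log units; beyond the scatter) and a 10-fold higher number from compound 1 to compound 4 (1.00 log units; beyond the scatter), so compound 1 with its phenethylcarbonyl group keeps the lowest number. Nothing measured here explains these steps.

The sulfonyl link and the thiophen-2-yl ring enter together, and their shares remain unseparated. From the compounds shown here alone, how phenylsulfonyl or methylsulfonyl would read on this nitrogen stays open.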